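The source may report more compounds than this note shows. Statements on the series, on what has been measured and on what is new or still open speak of the compounds shown alone.

Compound 1 `CNc1nnc(Cn2c(=O)oc3ccc(C)cc32)s1`: 96%
Compound 2 `CCNc1nnc(Cn2c(=O)oc3ccc(C)cc32)s1`: 94%

Of the compounds shown here, two have so far been measured in a functional assay on the whole organism with Mus musculus as the target, read by paw edema, with a stated time of 360 min, at a dose of 50 mg/kg by the oral route; on this read-out higher numbers stand for a weaker effect at the one dose given and lower numbers for a stronger effect. Compound 1 gives 96% in this assay, and compound 2 gives 94%. The step of a number 2 percentage points lower from compound 1 to compound 2 (within the scatter) shows that these two numbers lie within the scatter of each other, so on this read-out compound 2 cannot be told apart from compound 1.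

Compound 3 `CCCNc1nnc(Cn2c(=O)oc3ccc(C)cc32)s1` has not yet been measured. It differs from compound 2 by methyl in place of hydrogen on a saturated chain carbon, two bonds along the chain from a nitrogen on an aromatic ring. Going by the values given here, the one measured step that bears on this change is a number 2 percentage points lower from compound 1 to compound 2 (within the scatter), where going from methylamino to ethylamino gave a number that stayed within the scatter. Going from ethylamino to propylamino is therefore expected to behave alike, and compound 3 is expected to show a number 1 percentage points lower from compound 2 to compound 3 (within the scatter), a step of no size beyond the scatter. The estimate for compound 3 is 93%, expected to fall between 84% and 99%.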

Compound 3, a percentage reported as activity, at one dose (the size of the read-out at that dose, not a potency): 110%
Estimate against measurement, compound 3: 17 percentage points below; measured number outside the range, above it.
By their numbers in this assay, from the lowest: compounds 2 and 1 (each within the scatter of the next); then compound 3.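

In this assay, putting a methyl on the end of this chain does not always leave the number unchanged: going from ethylamino to propylamino gives a number 16 percentage points higher from compound 2 to compound 3 (beyond the scatter), although the earlier change from methylamino to ethylamino stayed within the scatter. The larger change, ethyl in place of hydrogen, gives a number 14 percentage points higher from compound 1 to compound 3 (beyond the scatter), so propylamino stands apart from both shorter chains, on the side of a weaker effect at the one dose given. Nothing at hand explains why this change counts here when the earlier one did not.

As far as these compounds go, whether a longer chain such as butylamino moves the number further in the same direction, or a branched group such as isopropylamino behaves like propylamino, stays open. Also open, from the compounds shown here alone, is whether a plain amino group on the same carbon of the ring would differ from compound 1 and compound 2.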